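From pyridin-4-yl to 2-(pyridin-3-yl)ethynyl on the shared core

The source may report more compounds than this note shows. Statements on the series, on what has been measured and on what is new or still open speak of the compounds shown alone.

In an ADME assay (liver) for metabolic stability, with Liver microsome (Homo sapiens) as the target, read by LC-MS, using microsomes, with a stated time of 30 min (on this read-out higher numbers stand for fast clearance and lower numbers for slow clearance), three compounds sharing one core have been measured. Compound 1 `CNC(=O)[C@@H](NC(=O)[C@@](O)(CCCN(Cc1ccc(Br)cc1)NC(=O)[C@@H](NC(=O)OC)C(C)(C)C)Cc1ccccc1)C(C)(C)C` carries a bromo group and stands at 180 mL.min-1.g-1 on this scale. Compound 2 `CNC(=O)[C@@H](NC(=O)[C@@](O)(CCCN(Cc1ccc(-c2cccnc2)cc1)NC(=O)[C@@H](NC(=O)OC)C(C)(C)C)Cc1ccccc1)C(C)(C)C` carries pyridin-3-yl and stands at 63 mL.min-1.g-1 while compound 3 `CNC(=O)[C@@H](NC(=O)[C@@](O)(CCCN(Cc1ccc(-c2ccncc2)cc1)NC(=O)[C@@H](NC(=O)OC)C(C)(C)C)Cc1ccccc1)C(C)(C)C` carries pyridin-4-yl and stands at 20 mL.min-1.g-1 as the lowest of the three and so the most slowly cleared.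

Compound 4 `CNC(=O)[C@@H](NC(=O)[C@@](O)(CCCN(Cc1ccc(C#Cc2cccnc2)cc1)NC(=O)[C@@H](NC(=O)OC)C(C)(C)C)Cc1ccccc1)C(C)(C)C` has not been measured yet. It takes 2-(pyridin-3-yl)ethynyl in place of pyridin-4-yl on an aromatic carbon on the same aromatic carbon. Replacing bromo gave a 2.9-fold lower number from compound 1 to compound 2 (0.46 log units; beyond the scatter) with pyridin-3-yl and a 9.0-fold lower number from compound 1 to compound 3 (0.95 log units; beyond the scatter) with pyridin-4-yl. The closest guide is a 3.2-fold lower number from compound 2 to compound 3 (0.50 log units; beyond the scatter) for the swap between the two pyridine groups alone. Compound 4 holds a pyridin-3-yl ring, so that step suggests it will lie above compound 3 by a similar size. For the measured compounds named here, no measured compound holds a triple bond, so that part of the change is untested and the range must stay wide. A step of a 2.8-fold higher number from compound 3 to compound 4 (0.44 log units; beyond the scatter) is therefore expected in this assay towards faster clearance. Compound 4 is estimated at 55 mL.min-1.g-1 with 20 mL.min-1.g-1 to 150 mL.min-1.g-1 as its expected range.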

Compound 4, intrinsic clearance in microsomes: > 300 mL.min-1.g-1
Compound 4 was reported as a limit (the forecaster's own chance of this, stated with the estimate: 3%); middle value at least 5.4-fold (0.73 log units) away from the limit.
By their numbers in this assay, from the lowest: compound 3; then compound 2; then compound 1. At a limit, above all of these: compound 4.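

In this assay the result for compound 4 is a limit and not a number: the limit of > 300 mL.min-1.g-1 in this assay, at which 1 of the 4 values shown sits.

Even so, the limit is enough to show something the earlier compounds could not, since they held only a bromo group or a pyridine ring on this aromatic carbon, para to a large group, and the two pyridine compounds gave the lowest numbers. Adding the triple bond removes that advantage, with an at least 4.7-fold higher number from compound 2 to compound 4 (0.67 log units; beyond the scatter) for the same pyridin-3-yl ring and an at least 15-fold higher number from compound 3 to compound 4 (1.17 log units; beyond the scatter) against the best compound of the set. The comparison with the bromo group gives an at least 1.6-fold higher number from compound 1 to compound 4 (0.22 log units; that floor lies within the scatter), so a pyridine ring on this carbon does not by itself ensure a number below that of compound 1.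

The compounds shown cannot separate the effect of the triple bond from that of the other added atoms, and a 2-(pyridin-3-yl)ethyl chain, which has no triple bond, would address that question. From the compounds shown here alone, it also remains open whether the advantage of pyridin-4-yl over pyridin-3-yl would carry over to a 2-(pyridin-4-yl)ethynyl group.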